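From Phenyl to Pyridin-3-yl in Microsomal Clearance

The source may hold more compounds than are shown below. What is called first, only, known or untested is meant among the compounds shown, and "the series" means these compounds.

In an ADME assay (liver) for metabolic stability, with Liver microsome (Rattus norvegicus) as the target, using microsomes (on this read-out higher numbers stand for fast clearance and lower numbers for slow clearance), compound 3 (`c1ccc(CNc2nnc(-c3c[nH]c4ncccc34)o2)cc1`) gives 40 mL.min-1.g-1. Compound 1 (`Nc1n[nH]c2ccc(-c3nnc(NCc4ccccc4)o3)cc12`) gives 74 mL.min-1.g-1, a number within the usual scatter of that for compound 3, so the two cannot be told apart. Compound 2 (`O=C1Cc2cc(-c3nnc(NCc4ccccc4)o3)ccc2N1`) returns only a limit of the assay, < 14 mL.min-1.g-1.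

Compound 4 (`c1cncc(CNc2nnc(-c3c[nH]c4ncccc34)o2)c1`) departs from compound 3 in one place: pyridin-3-yl in place of phenyl on a saturated chain carbon bound to a nitrogen on an aromatic ring. The change puts pyridin-3-yl in place of phenyl on a saturated chain carbon bound to a nitrogen on an aromatic ring, which reads equally as benzyl to (pyridin-3-yl)methyl. No measured pair among these compounds shows this change, so the expectation in this assay rests on compound 3 and its 40 mL.min-1.g-1 alone. What is expected is a moderate move toward slower clearance, a 1.5-fold lower number from compound 3 to compound 4 (0.19 log units; within the scatter), which may well stay within the scatter. For compound 4 the estimated value is 26 mL.min-1.g-1, with an expected range from 12 mL.min-1.g-1 to 55 mL.min-1.g-1.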

Compound 4, intrinsic clearance in microsomes: 30 mL.min-1.g-1
Estimate against measurement, compound 4: 1.2-fold (0.06 log units) below, and the stated range covers the measured number.
By their numbers in this assay, from the lowest: compounds 4, 3 and 1 (each within the scatter of the next, the first and the last beyond it). At a limit, below all of these: compound 2.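

In this assay, for the compounds shown here, pyridin-3-yl in place of phenyl on a saturated chain carbon bound to a nitrogen on an aromatic ring gives a 1.3-fold lower number from compound 3 to compound 4 (0.12 log units; within the scatter), the first reading of any change at this position. Exchanging phenyl for a ring with one hetero atom, at the same count of heavy atoms, therefore leaves the read-out indistinguishable from that of compound 3. This pair is read from two measured numbers, as the limit of the assay is reached only by compound 2: the limit of < 14 mL.min-1.g-1 in this assay, at which 1 of the 4 values shown sits.

As far as these compounds go, what a pyridin-4-yl, a pyridin-2-yl or a longer chain would give at this place remains open, as does the effect of a carboxylic acid or an amine on the ring. Equally open, from the compounds shown here alone, is whether the same change would read alike on the core of compound 1 or compound 2.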